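Notes on the ester group of compound 2

The compounds below may be only part of what the source reports. "The series", "measured", "known", "first", "only" and "open" are said of these compounds alone.

Of the compounds shown here, two of the shared core have been measured in an assay on membranes from HeLa cells for displacement of a labelled ligand from adenosine receptor A3 (Homo sapiens), read by scintillation counting, with a stated time of 180 min, tested at 1 uM; on this read-out lower numbers stand for less inhibition and higher numbers for more inhibition at the one concentration tested (going by the name of the read-out). Compound 1 `COC(=O)C1=C(C)N(C)C(=O)NC1c1ccco1` gives 9%. Compound 2 `COC(=O)C1=C(C)N(C)C(=O)NC1c1cccs1` gives 15%. The step between them, a number 6 percentage points higher from compound 1 to compound 2 (within the scatter), leaves the two numbers within the scatter of each other, so compound 2 is not set apart from compound 1 on the numbers shown. Compound 3 `CC1=C(C(=O)OC(C)(C)C)C(c2cccs2)NC(=O)N1C` carries the change (tert-butyl in place of methyl on an oxygen next to a carbonyl group). Among the measured compounds shown here, no measured step touches that oxygen. For the measured compounds named here, the only measured step, a number 6 percentage points higher from compound 1 to compound 2 (within the scatter), concerns the saturated ring carbon and was within the scatter, and both measured numbers are low. The data therefore give no ground to expect a step beyond the scatter in this assay in either direction. For compound 3 the expected number is 15%, with a range from 0% to 35%. The expected step is no change at the digits printed from compound 2 to compound 3 (within the scatter).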

Compound 3, a percentage reported as inhibition, at one concentration (the size of the read-out at that concentration, not a potency): 22%
The estimate for compound 3 lay 7 percentage points below the measured number; measured number inside the range.
By their numbers in this assay, from the lowest: compounds 1, 2 and 3 (each within the scatter of the next, the first and the last beyond it).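

Among the compounds shown here, the change of tert-butyl in place of methyl on an oxygen next to a carbonyl group gives a number 7 percentage points higher from compound 2 to compound 3 (within the scatter) in this assay, and this is the only measured step at this oxygen. The ester position therefore carries tert-butyl, with 4 heavy atoms where methyl has 1, without a step beyond the scatter. Nothing available explains this result.

On these data alone, whether a free carboxylic acid, a primary amide or a longer straight chain such as n-butyl at this place would give a step beyond the scatter remains open. For the compounds shown here, with methyl and tert-butyl as the only two groups compared here, the series also leaves open how ethyl or isopropyl would read in this assay.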